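Carboxy to tetrazolyl on the branched chain of compound 3

The source may hold more compounds than are shown below. What is called first, only, known or untested is meant among the compounds shown, and "the series" means these compounds.

Compound 3 `CCCc1c(COc2ccc(C(=O)CC(C)(C)CC(=O)O)cc2)ccc(C(C)=O)c1O` gives 7.73 in a functional assay on ileum (Cavia porcellus) with cysteinyl leukotriene receptor (Homo sapiens) as the target (on this read-out lower numbers stand for lower potency and higher numbers for higher potency (the scale is a negative logarithm)), the highest of the three numbers shown. Compound 2 `CCCc1c(COc2ccc(C(=O)CCCC(=O)O)cc2)ccc(C(C)=O)c1O` gives 6.81 and compound 1 `CCCc1c(COc2ccc(C(=O)CCC(=O)O)cc2)ccc(C(C)=O)c1O` gives 6.75 in this assay. The steps of a number 0.98 log units higher from compound 1 to compound 3 (beyond the scatter) and a number 0.92 log units higher from compound 2 to compound 3 (beyond the scatter) lie beyond the scatter, whereas a number 0.06 log units higher from compound 1 to compound 2 (within the scatter) lies within it. Compound 4 `CCCc1c(COc2ccc(C(=O)CC(C)(C)Cc3nnn[nH]3)cc2)ccc(C(C)=O)c1O` differs from compound 3 by 1H-tetrazol-5-yl in place of carboxy on a saturated chain carbon, three bonds along the chain from a carbonyl carbon. Among the compounds with values here, none of the measured steps touches the acid group itself; they vary only chain length and branching, so no step bears directly on this change. The expected step is a number 0.03 log units lower from compound 3 to compound 4 (within the scatter), with a wide range. Compound 4 is therefore estimated at 7.7 in this assay, between 7 and 8.4.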

Compound 4, negative logarithm of the antagonist equilibrium constant: 7.86
Estimate against measurement, compound 4: 0.16 log units below, and the stated range covers the measured number.
By their numbers in this assay, from the lowest: compounds 1 and 2 (each within the scatter of the next); then compounds 3 and 4 (each within the scatter of the next).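

In this assay, within the data shown here, the first change to the carboxy group itself, to 1H-tetrazol-5-yl, gives a number 0.13 log units higher from compound 3 to compound 4 (within the scatter) and so leaves the read-out unchanged within the scatter at this position. The gain seen with the branched chain persists with the new group, with a number 1.05 log units higher from compound 2 to compound 4 (beyond the scatter) and a number 1.11 log units higher from compound 1 to compound 4 (beyond the scatter) on the same read-out. Nothing available explains why the two groups match.

Open, from the compounds shown here alone, is whether 1H-tetrazol-5-yl also matches carboxy on the unbranched chains of compound 1 and compound 2. Also open, going by these compounds, is how an acyl sulfonamide or a hydroxamic acid would fare at this position.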